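The compounds below may be only part of what the source reports. "The series", "measured", "known", "first", "only" and "open" are said of these compounds alone.

Measured so far, in an assay on cells for binding affinity to metabotropic glutamate receptor 2 (Homo sapiens), read by scintillation proximity assay; a higher number here means weaker binding, a lower number tighter binding:
- compound 2 `CC(C)Nc1ccc(-c2ccn3c(CC4CC4)nnc3c2C(F)(F)F)cc1F`: 2.2 nM
- compound 1 `CC(C)Nc1ccc(-c2ccn3c(CC4CC4)nnc3c2Cl)cc1F`: 20.3 nM

Going by the values given here, compound 2 stands lowest of the two numbers in this assay; the only neighbour is compound 1, which gives the higher number. Among the compounds with values here, the single measured step, a 9.2-fold lower number from compound 1 to compound 2 (0.97 log units; beyond the scatter), is trifluoromethyl in place of chloro on an aromatic carbon of the shared core and is the only guide to how this series responds at all.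

Compound 3 `CC(C)Nc1ccc(-c2ccn3c(CC4CC4)nnc3c2C(F)(F)F)cc1Cl` has not been measured. It differs from compound 2 by chloro in place of fluoro on an aromatic carbon, that is, on the six-membered aromatic ring of carbon only, ortho to an isopropylamino group and meta to a large group. Within the data shown here, the measured step from compound 1 to compound 2 sits on a different ring and swaps different groups, so it does not bear directly on this change; no measured pair varies the halogen at this place. With nothing to anchor a large shift, the expectation for compound 3 is a step no larger than the scatter, a 1.4-fold higher number from compound 2 to compound 3 (0.13 log units; within the scatter), in either direction. The estimate for compound 3 in this assay is 3 nM, with a range from 1.2 nM to 8 nM.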

Compound 3, dissociation constant: 3.4 nM
Beside the measured number, compound 3's estimate is 1.1-fold (0.05 log units) below it; low and high end bracket the measured number.
By their numbers in this assay, from the lowest: compounds 2 and 3 (each within the scatter of the next); then compound 1.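

In this assay, the place on the six-membered aromatic ring of carbon only, ortho to an isopropylamino group and meta to a large group, now has its first measured halogen exchange: chloro in place of fluoro gives a 1.5-fold higher number from compound 2 to compound 3 (0.19 log units; within the scatter) and so leaves compound 2 and compound 3 level within the scatter. With trifluoromethyl on the shared core, this place therefore accepts either halogen without a change that the assay can resolve, in contrast to the earlier step on a different ring, a 9.2-fold lower number from compound 1 to compound 2 (0.97 log units; beyond the scatter), which lies beyond the scatter. Nothing measured at hand accounts for this result.

Still open, going by these compounds, is whether this tolerance extends beyond the two halogens, for instance to a methoxy group, a nitrile or a primary amine at the same place. Also open, on these data alone, are whether fluoro and chloro remain level here when chloro replaces trifluoromethyl on the shared core, and whether the isopropylamino group can give way to a cyclopropylamino group or a longer chain.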